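Swapping the aryl group on the amide of an indole-piperidine series

A few compounds are considered here, and "the series" means these few. Any claim that something is new, unique, unknown or untested is made for them only; others in the source may bear on it.

Of the compounds shown here, three sharing one core have been measured in an assay for binding affinity to 5-hydroxytryptamine receptor 1B (Homo sapiens), read by radioligand binding; on this read-out higher numbers stand for weaker inhibition and lower numbers for stronger inhibition. Compound 1 `CCCCCCCC(=O)Nc1ccc2[nH]cc(C3CCN(C)CC3)c2n1` carries a heptyl chain on the carbonyl carbon and gives 32 nM. Compound 2 `COc1ccccc1C(=O)Nc1ccc2[nH]cc(C3CCN(C)CC3)c2n1` replaces that chain with a 2-methoxyphenyl group and gives 750 nM. Compound 3 `CN1CCC(c2c[nH]c3ccc(NC(=O)c4cccc(F)c4)nc23)CC1` carries a 3-fluorophenyl group instead and gives 1600 nM, the highest number of the three, so its binding is the weakest seen so far.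

Compound 4 `CN1CCC(c2c[nH]c3ccc(NC(=O)c4ccc(C#N)cc4)nc23)CC1` is not yet measured. It differs from compound 3 in one place: 4-cyanophenyl in place of 3-fluorophenyl on a carbonyl carbon. Among the compounds with values here, the steps that bear on this are the aryl-for-chain replacements, a 23-fold higher number from compound 1 to compound 2 (1.37 log units; beyond the scatter) and a 50-fold higher number from compound 1 to compound 3 (1.70 log units; beyond the scatter), which were large, and the aryl-for-aryl swap, a 2.1-fold higher number from compound 2 to compound 3 (0.33 log units; beyond the scatter), which was modest. Compound 4 keeps an aryl group, so the expected change in this assay is modest, with the direction uncertain. The estimate for compound 4 is 1500 nM, expected to fall between 500 nM and 5000 nM, which for compound 4 implies an expected step of a 1.1-fold lower number from compound 3 to compound 4 (0.03 log units; within the scatter).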

Compound 4, inhibition constant: 310 nM
Compound 4: the middle estimate sits 4.8-fold (0.68 log units) above what was measured; the measured number lies below the stated range.
By their numbers in this assay, from the lowest: compound 1; then compound 4; then compound 2; then compound 3.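

In this assay, the aryl groups at this position are not interchangeable: 4-cyanophenyl gives a 5.2-fold lower number from compound 3 to compound 4 (0.71 log units; beyond the scatter) against 3-fluorophenyl and a 2.4-fold lower number from compound 2 to compound 4 (0.38 log units; beyond the scatter) against 2-methoxyphenyl, so the choice of aryl group shifts the number beyond the scatter. The heptyl chain still holds the lowest number, with a 9.7-fold higher number from compound 1 to compound 4 (0.99 log units; beyond the scatter), so 4-cyanophenyl recovers only part of the gap seen earlier between the chain and the aryl groups. Nothing available explains why 4-cyanophenyl differs from the other two aryl groups.

The aryl groups shown differ in both substituent and name position, so the contribution of the nitrile alone stays unresolved. As far as these compounds go, whether a plain phenyl group or a shorter propyl chain on the carbonyl carbon would land nearer compound 1 or compound 4 also remains open.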